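Solubility notes: methyl in place of fluoro

The compounds below may be only part of what the source reports. "The series", "measured", "known", "first", "only" and "open" are said of these compounds alone.

compound 1 `Cc1cc(NCc2ccccn2)n2ncc(-c3ccc(F)cc3F)c2n1` — < 5000 nM
compound 2 `CCN1CCCC1CNc1cc(C)nc2c(-c3ccccc3)c(C)nn12` — 172000 nM

In a physicochemical assay for solubility, read by HPLC, using the shake flask method, measured as kinetic solubility, with a stated time of 2 h, at pH 7.4 (a lower number here means a less soluble compound, a higher number a more soluble compound), compound 1 gives only a limit, < 5000 nM, so no number for its solubility is known. Compound 1 sits at the limit of < 5000 nM in this assay, at which 1 of the 2 values shown sits. In this assay compound 2 gives 172000 nM. Going by the values given here, no step between measured compounds is available; the two values show only that compound 2 is reported as a number and compound 1 as a limit.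

Compound 3 `Cc1cc(NCc2ccccn2)n2ncc(-c3ccc(F)cc3C)c2n1` has not been measured in this assay. It differs from compound 1 by methyl in place of fluoro on an aromatic carbon.

Among the compounds with values here, no measured step guides the size of this change. The step that the limit leaves unreadable from compound 1 to compound 3 is expected to be small, within the usual scatter, if anything toward lower solubility. Compound 3 is therefore expected to give 3000 nM, in a range from 700 nM to 10000 nM, and is likely to be reported again as a limit.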

Compound 3, solubility: 42300 nM
For compound 3 the middle estimate is 14-fold (1.15 log units) below the measured one; the whole stated range lies below it.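

In this assay, going by these compounds alone, the change from 2,4-difluorophenyl to 4-fluoro-2-methylphenyl gives an at least 8.4-fold higher number from compound 1 to compound 3 (0.92 log units; beyond the scatter), the first readable step and one that lies beyond the scatter. A single heavy atom exchanged on an aromatic carbon, ortho to a large group, is therefore enough to move this read-out clearly, with no ring, hydrogen-bond donor, hydrogen-bond acceptor or net charge entering or leaving. The true size of the step stays unknown, and only its lower bound can be read, because compound 1 is reported only as a limit: the limit of < 5000 nM in this assay, at which 1 of the 3 values shown sits.

The compounds shown leave open how other groups at this place would read, such as chloro, methoxy or a small amine. On these data alone, whether methyl in place of fluoro gives a similar step elsewhere on the shared core also remains open.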